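The compounds below may be only part of what the source reports. "The series", "measured", "known", "first", "only" and "open" are said of these compounds alone.

Compound 2 `O=C(O)c1ccc(COc2ccc(CNC(=O)[C@@H]3CCC(=O)N3Cc3ccc(F)cc3)cc2)cc1` carries a 4-fluorobenzyl group on an amide-type nitrogen in a ring of the shared core. In an assay on HEK293 cells for inhibition of Ataxin-2 (Mus musculus), read by fluorescence and Amplex Red (a lower number here means a stronger inhibitor, a higher number a weaker inhibitor), compound 2 gives > 5000 nM, which is a limit of the assay rather than a number. Compound 1 `O=C(O)c1ccc(COc2ccc(CNC(=O)[C@@H]3CCC(=O)N3Cc3ccc(Br)cc3)cc2)cc1` carries bromo in place of that fluoro. In this assay compound 1 gives > 5000 nM, also a limit. The step that the two limits leave unreadable from compound 1 to compound 2 cannot be read, since both values sit at the limit of > 5000 nM in this assay, at which 2 of the 2 values shown sit. Compound 3 `O=C1CC[C@@H](C(=O)NCc2ccc(OCc3ccc(C(=O)O)cc3)cc2)N1` differs from compound 2 by hydrogen in place of 4-fluorobenzyl on an amide-type nitrogen in a ring. Among the compounds with values here, no measured step bears on this change, so neither direction nor size is known. Compound 3 is expected to give 8000 nM, between 2500 nM and 30000 nM. That expectation means a step that the limit leaves unreadable from compound 2 to compound 3, itself uncertain.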

Compound 3, half-maximal inhibitory concentration: > 5000 nM
Compound 3: a limit, no number (the forecaster's own chance of this, stated with the estimate: 80%); the middle value lies beyond the limit too.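

In this assay compound 3 gives > 5000 nM, which is a limit and not a number. Within the data shown here, no step among compound 1, compound 2 and compound 3 can therefore be read: the limit of > 5000 nM in this assay, at which 3 of the 3 values shown sit. Going by these compounds, whether 4-bromobenzyl, 4-fluorobenzyl or hydrogen on that ring nitrogen changes the inhibition stays open.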